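This account rests on a few compounds, and the source may have more. Where it says the series, first, only, none or still open, it means among the compounds named here.

Working notes on the series.

Compound 1 `COC(=O)c1sc2cc(C#Cc3ccccc3OC)cnc2c1N` and compound 2 `COC(=O)c1sc2cc(C#Cc3ccccc3N)cnc2c1N` share one core; compound 3 `COC(=O)c1sc2cc(C#Cc3ccccc3)cnc2c1N` is not yet measured. Going by the values given here, in a functional assay on NCI-H460 cells (Homo sapiens) for inhibition, read by sulforhodamine B assay, with a stated time of 48 h (on this read-out higher numbers stand for weaker inhibition of growth and lower numbers for stronger inhibition of growth), compound 2 gives 5700 nM, the only plain number so far. For compound 1 this assay reports > 47300 nM, which is a limit of the assay and not a number (the limit of > 47300 nM in this assay, at which 1 of the 2 values shown sits). Among the compounds with values here, the single measured step, an at least 8.2-fold lower number from compound 1 to compound 2 (0.91 log units; beyond the scatter), is the only guide available.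

The step to compound 3 is hydrogen in place of amino on an aromatic carbon, sitting on an aromatic carbon of a six-membered aromatic ring of carbon only, ortho to a large group. The measured step replaced methoxy with amino and gave a clearly lower number; the present step removes that amino for hydrogen, so the expected direction is toward a higher number, of uncertain size. The expected step is a 3.5-fold higher number from compound 2 to compound 3 (0.55 log units; beyond the scatter). Compound 3 is estimated at 20000 nM, between 6000 nM and 70000 nM.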

Compound 3, concentration for 50% growth inhibition: > 150000 nM
Compound 3 was reported as a limit (the forecaster's own chance of this, stated with the estimate: 30%); middle value at least 7.5-fold (0.87 log units) from the limit.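

In this assay, the change from 2-aminophenyl to phenyl gives an at least 26-fold higher number from compound 2 to compound 3 (1.42 log units; beyond the scatter); this shows that the lower number of compound 2 goes with the amino group itself, as neither methoxy nor hydrogen at this place gives a plain number. Compound 3 stands at a limit of the assay and not a number, and the full size of the step is not given: the limit of > 150000 nM in this assay, at which 1 of the 3 values shown sits. Compound 1 also stands at a limit of the assay, and the step from it to compound 3 cannot be read: the limit of > 47300 nM in this assay, at which 1 of the 3 values shown sits.

A hydroxyl, a methylamino or an acetamido group on the same aromatic carbon would show how closely the lower number is tied to amino. On these data alone, with a single plain number in the set, how far any group here can lower it remains open.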